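Mouse Liver Microsome Half-life: From Compound 2 to Compound 3

The source may hold more compounds than are shown below. What is called first, only, known or untested is meant among the compounds shown, and "the series" means these compounds.

Measured so far in an ADME assay on microsomes from liver (Mus musculus, strain CD1) for metabolic stability, read by LC-MS, using NADPH, with a stated time of 60 min; on this read-out higher numbers stand for a longer-lived compound and lower numbers for a shorter-lived compound:
Compound 1 `Cc1c(C)n(Cc2ccccc2)c2ncn(C3CCOCC3)c(=N)c12` gives 0.448 h.
Compound 2 `N=c1c2c(-c3ccccc3)c(-c3ccccc3)n(CC3CC3)c2ncn1CC1CCOCC1` gives 0.272 h.

Compound 2 has the lowest of the two numbers in this assay, but its nearest neighbour, compound 1, lies within the scatter of it, so the two values cannot be placed in order; they are read as the same. For the measured compounds named here, no step between two measured compounds differing in one place is available, so nothing is known about what any single change does to the half-life here.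

Compound 3 `COc1ccc(Cn2c(-c3ccccc3)c(-c3ccccc3)c3c(=N)n(CC4CCOCC4)cnc32)cc1` is the compound not yet measured. It differs from compound 2 in one place: 4-methoxyphenyl in place of cyclopropyl on a saturated chain carbon bound to an aromatic nitrogen. Going by the values given here, with no measured step to lean on, and with compound 1 and compound 2 sitting so close together, the expectation is that this change moves the half-life by no more than the scatter, in either direction. The step from compound 2 to compound 3 is therefore expected to be a 1.0-fold lower number from compound 2 to compound 3 (0.02 log units; within the scatter). For compound 3 in this assay the estimated value is 0.26 h, with a range from 0.12 h to 0.55 h.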

Compound 3, half-life: 0.217 h
Estimate against measurement, compound 3: 1.2-fold (0.08 log units) above, and the stated range covers the measured number.
By their numbers in this assay, from the lowest: compounds 3, 2 and 1 (each within the scatter of the next, the first and the last beyond it).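

In this assay, for the compounds shown here, the exchange of cyclopropyl for 4-methoxyphenyl on a saturated chain carbon bound to an aromatic nitrogen gives the first single-place step in this set, a 1.3-fold lower number from compound 2 to compound 3 (0.10 log units; within the scatter). The earlier compounds shown here could not show this, as they differ from each other in more than one place; now it can be said that replacing a three-membered non-aromatic ring of carbon with a six-membered aromatic ring carrying a methoxy group produces no difference that can be told from the scatter in this half-life. No measurement shown here accounts for this result.

The compounds shown leave open whether this position would respond to a group of a different kind, such as an amine or a carboxylic acid on the chain, since a single step between two neutral groups says nothing about those. From the compounds shown here alone, it also remains open whether the same exchange would read alike on the core of compound 1, which differs from compound 2 in more than one place.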